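The source may report more compounds than this note shows. Statements on the series, on what has been measured and on what is new or still open speak of the compounds shown alone.

Compound 1 `Brc1cn2ccnc2c(-c2ccc3ncn(C4CCCCC4)c3c2)n1` is the reference point of this short series. In a functional assay on UO-31 cells (Homo sapiens) for inhibition, read by sulforhodamine B assay, with a stated time of 48 h, tested at 10 uM (a higher number here means more inhibition at the concentration tested (going by the name of the read-out), a lower number less inhibition), compound 1 gives 37.6%, the second highest of three numbers. Compound 2 `O=Cc1ccc(-c2cn3ccnc3c(-c3ccc4ncn(C5CCCCC5)c4c3)n2)cc1` gives 82.2%, and compound 3 `c1cn2cc(-c3ccsc3)nc(-c3ccc4ncn(C5CCCCC5)c4c3)c2n1` gives 23.1%. Compound 4 `Fc1ccccc1-c1cn2ccnc2c(-c2ccc3ncn(C4CCCCC4)c3c2)n1` has not yet been measured; it differs from compound 1 in one place: 2-fluorophenyl in place of bromo on an aromatic carbon.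

Within the data shown here, two measured steps bear on this change, as each also swaps the bromo for an aromatic ring at the same carbon. There was a number 44.6 percentage points higher from compound 1 to compound 2 (beyond the scatter), while there was a number 14.5 percentage points lower from compound 1 to compound 3 (beyond the scatter). The two steps point in opposite directions, so the aromatic ring alone does not settle the outcome. The six-membered carbon ring of compound 2 is the closer match to 2-fluorophenyl, yet its formyl is missing in compound 4, so only part of that large rise seems due to a number 44.6 percentage points higher from compound 1 to compound 2 (beyond the scatter) transferring.

On balance a rise is expected, estimated as a number 14.4 percentage points higher from compound 1 to compound 4 (beyond the scatter). The expected value for compound 4 is therefore 52%, within a range from 25% to 78%.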

Compound 4, a percentage reported as inhibition, at one concentration (the size of the read-out at that concentration, not a potency): 22.9%
For compound 4 the middle estimate is 29.1 percentage points above the measured one; the whole stated range lies above it.
By their numbers in this assay, from the lowest: compounds 4 and 3 (each within the scatter of the next); then compound 1; then compound 2.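

In this assay there is a number 14.7 percentage points lower from compound 1 to compound 4 (beyond the scatter) when 2-fluorophenyl enters, so an aromatic ring at this carbon does not by itself raise the number. There is also a number 0.2 percentage points lower from compound 3 to compound 4 (within the scatter) when 2-fluorophenyl replaces thiophen-3-yl, so these two groups cannot be told apart here. With a number 59.3 percentage points lower from compound 2 to compound 4 (beyond the scatter) when 2-fluorophenyl replaces 4-formylphenyl, compound 2 now stands alone among these four compounds, and nothing measured here gives a reason for that.

Going by these compounds, it remains open whether the high number depends on the formyl group or on some other feature of 4-formylphenyl. A plain phenyl, or a phenyl carrying a carboxylic acid or an amine where compound 2 has its formyl, would help to separate these possibilities.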